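Removing the ring fluorine from compound 1

A few compounds are considered here, and "the series" means these few. Any claim that something is new, unique, unknown or untested is made for them only; others in the source may bear on it.

Compound 1 `O=C(O)CCc1ccc(C#Cc2ccnc(F)c2)cc1` gives 513 nM in an in vitro functional assay on 1321-N1 cells for agonist activity at Free fatty acid receptor 1 (Homo sapiens), read by fluorescence, spectrophotometry and calcium flux (on this read-out lower numbers stand for an effect already at smaller amounts and higher numbers for an effect only at larger amounts of compound), the highest of the two numbers recorded so far. Going by the values given here, its nearest neighbour on that scale is compound 2 `Cc1cnc(F)cc1C#Cc1ccc(CCC(=O)O)cc1`, which gives 178 nM in this assay; the step of a 2.9-fold lower number from compound 1 to compound 2 (0.46 log units; beyond the scatter) is the only measured step and concerns a methyl in place of hydrogen on an aromatic carbon.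

Compound 3 `O=C(O)CCc1ccc(C#Cc2ccncc2)cc1` has not been measured. It differs from compound 1 by hydrogen in place of fluoro on an aromatic carbon. Among the compounds with values here, no measured pair covers this change: the step of a 2.9-fold lower number from compound 1 to compound 2 (0.46 log units; beyond the scatter) alters a different position and so does not bear on it directly; it shows only that a single small change on the shared core of compound 1 can shift the number by a modest amount. With nothing directly comparable, no step beyond the scatter is expected in this assay in either direction, and the estimate stays near compound 1 with a wide range. Compound 3 is expected to give 450 nM in this assay, within a range of 150 nM to 1300 nM, which amounts to an expected step of a 1.1-fold lower number from compound 1 to compound 3 (0.06 log units; within the scatter).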

Compound 3, half-maximal effective concentration: 4070 nM
The estimate for compound 3 lay 9.0-fold (0.96 log units) below the measured number, outside the stated range (above it).
By their numbers in this assay, from the lowest: compound 2; then compound 1; then compound 3.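

In this assay, replacing the fluoro next to the ring nitrogen with hydrogen gives a 7.9-fold higher number from compound 1 to compound 3 (0.90 log units; beyond the scatter) and so shows that this position is sensitive to substitution, with the fluoro of compound 1 going with the lower number. Going by these compounds alone, until now the only measured change on the shared core was a 2.9-fold lower number from compound 1 to compound 2 (0.46 log units; beyond the scatter) at a different aromatic carbon; the new step runs in the opposite direction and shows that removing one heavy atom from the ring can also raise the number beyond the scatter. Nothing available on these compounds accounts for the step, so the data record its direction and size but no cause.

Open, as far as these compounds go, is whether chloro, methoxy or an amine in place of the fluoro next to the ring nitrogen would stand closer to compound 1 or to compound 3 on this scale. Also open, from the compounds shown here alone, is whether adding a methyl, which lowered the number when the fluoro was present, would do the same on the core of compound 3, or whether the two changes depend on each other.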